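This account rests on a few compounds, and the source may have more. Where it says the series, first, only, none or still open, it means among the compounds named here.

Measured in a functional assay on HCT-116 cells (Homo sapiens) for antiproliferative activity, read by MTT assay, with a stated time of 48 h; a lower number here means a stronger inhibitor, a higher number a weaker inhibitor:
- compound 1 `O=C(OCC(CCO)n1cnc2c(Cl)nc(F)nc21)c1ccccc1`: 5170 nM
- compound 2 `OCCC(COCc1ccccc1)n1cnc2c(Cl)ncnc21`: > 50000 nM, a limit of the assay

Compound 2 stands only at a limit, > 50000 nM, and has no numerical value. Compound 3 `O=C(OCC(CCO)n1cnc2c(Cl)ncnc21)c1ccccc1` has benzoyl in place of benzyl on an oxygen on a saturated carbon. Among the compounds with values here, no measured step covers this change. Compound 1 also carries benzoyl and gives 5170 nM, so a step toward stronger inhibition is expected in this assay. The expected step is an at least 4.1-fold lower number from compound 2 to compound 3 (0.61 log units; beyond the scatter). For compound 3 the estimate is 12000 nM, with an expected range of 3500 nM to 45000 nM.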

Compound 3, half-maximal inhibitory concentration: > 50000 nM
Compound 3: only a limit was reported; the forecaster's own chance of this, stated with the estimate: 15%; at least 4.1-fold (0.61 log units) between middle value and limit.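

In this assay, the step for benzoyl in place of benzyl on an oxygen on a saturated carbon cannot be read, because compound 2 and compound 3 both stand at a limit of the assay: the limit of > 50000 nM in this assay, at which 2 of the 3 values shown sit.

With benzoyl held fixed, hydrogen in place of fluoro on an aromatic carbon gives an at least 9.6-fold higher number from compound 1 to compound 3 (0.98 log units; beyond the scatter). Benzoyl alone therefore does not give a measurable value in this assay; among these compounds, only compound 1, with fluoro, does.

Going by these compounds, whether an amine on that aromatic carbon also gives a measurable value remains open. So does whether fluoro would have the same effect with the benzyl of compound 2.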